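Trifluoromethyl Added to the Chlorophenyl Urea of Compound 1

The source may report more compounds than this note shows. Statements on the series, on what has been measured and on what is new or still open speak of the compounds shown alone.

Compound 1, `O=C(NCCCCC(c1ccc(F)cc1)c1ccc(F)cc1)Nc1ccc(Cl)cc1`, gives 7680 nM in a functional assay on MDA-MB-231 cells (Homo sapiens) for cytotoxicity, read by MTT assay, with a stated time of 48 h; on this read-out higher numbers stand for weaker inhibition and lower numbers for stronger inhibition.
Compound 2, `Cc1cccc(NC(=O)NCCCCC(c2ccc(F)cc2)c2ccc(F)cc2)c1`, reaches only a limit of the assay in this assay, > 20000 nM.
Compound 3, `CC(=O)Nc1cc(NC(=O)NCCCCC(c2ccc(F)cc2)c2ccc(F)cc2)ccc1Cl`, gives 9120 nM in this assay.

Of the two numbers that are not limits, compound 1 has the lower one; compound 3 lies within the scatter of it, as a 1.2-fold higher number from compound 1 to compound 3 (0.07 log units; within the scatter) shows. Going by the values given here, the only step beyond the scatter is an at least 2.6-fold higher number from compound 1 to compound 2 (0.41 log units; beyond the scatter), where compound 2 gives a limit (the limit of > 20000 nM in this assay, at which 1 of the 3 values shown sits).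

Compound 4, `O=C(NCCCCC(c1ccc(F)cc1)c1ccc(F)cc1)Nc1ccc(Cl)cc1C(F)(F)F`, differs from compound 1 by trifluoromethyl in place of hydrogen on an aromatic carbon. Among the compounds with values here, no measured step adds a trifluoromethyl group, so the guide is indirect: the addition of an acetamido group on the 4-chlorophenyl of compound 1 gave a 1.2-fold higher number from compound 1 to compound 3 (0.07 log units; within the scatter), a change within the scatter. The step from compound 1 to compound 4 is therefore expected to be small, a 1.0-fold higher number from compound 1 to compound 4 (0.02 log units; within the scatter). Compound 4 is estimated at 8000 nM, with a range from 3500 nM to 20000 nM.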

Compound 4, half-maximal inhibitory concentration: > 20000 nM
Compound 4 ended at the assay's limit; the forecaster's own chance of this, stated with the estimate: 25%; middle value at least 2.5-fold (0.39 log units) from the limit.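

Trifluoromethyl in place of hydrogen, on an aromatic carbon ortho to a large group and meta to the chloro group, gives an at least 2.6-fold higher number from compound 1 to compound 4 (0.41 log units; beyond the scatter), the only step shown that adds a group to the 4-chlorophenyl ring and moves the number beyond the scatter. The acetamido group added to that ring left its step within the scatter, while exchanging the two substituted phenyl groups gives an at least 2.1-fold higher number from compound 3 to compound 4 (0.34 log units; beyond the scatter), so in this assay this ring does not take every added group alike. Compound 4 gives a limit of the assay, and the step between it and compound 2 cannot be read: the limit of > 20000 nM in this assay, at which 2 of the 4 values shown sit.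

Going by these compounds, it stays open whether a fluoro or methoxy group at this same place would give a similar step. Also open, on these data alone, is whether an amine or a carboxylic acid there would bring the number back towards that of compound 1.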